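Methyl to Trifluoromethyl: Carrying One Step Across Two Cores

The compounds below may be only part of what the source reports. "The series", "measured", "known", "first", "only" and "open" are said of these compounds alone.

In an assay on isolated protein for inhibition of Amine oxidase [flavin-containing] B (Homo sapiens), read by Amplex Red, with a stated time of 15 min (a higher number here means a weaker inhibitor, a lower number a stronger inhibitor), three compounds have been measured:
compound 1, `CC(=O)c1ccc(OCc2ccccc2C)cc1`, 77.1 nM
compound 2, `CC(=O)c1ccc(OCc2ccccc2C(F)(F)F)cc1`, 183 nM
compound 3, `CC(=O)c1cccc(OCc2cccc(C)c2)c1`, 893 nM

Compound 1 and compound 2 share a core and differ in a single group: trifluoromethyl in place of methyl on an aromatic carbon. That change gave a 2.4-fold higher number from compound 1 to compound 2 (0.38 log units; beyond the scatter), a modest step in this assay. Compound 3 has the same atoms as compound 1, joined differently; the difference between the two cores is not broken down here. In this assay compound 3 gives the highest of the three values.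

Compound 4, `CC(=O)c1cccc(OCc2cccc(C(F)(F)F)c2)c1`, has not yet been measured. It stands to compound 3 as compound 2 stands to compound 1: trifluoromethyl in place of methyl on an aromatic carbon. The place is not identical, though: in compound 2 the new group sits ortho to a large group, in compound 4 meta to a large group, so this is the same kind of change rather than the same change. The expectation for compound 4 rests only on the step of a 2.4-fold higher number from compound 1 to compound 2 (0.38 log units; beyond the scatter), carried over to the core of compound 3, with extra room for the different place. Compound 4 is therefore expected to show a 2.4-fold higher number from compound 3 to compound 4 (0.37 log units; beyond the scatter) in this assay. The estimated value for compound 4 is 2100 nM, expected to fall between 900 nM and 5000 nM.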

Compound 4, half-maximal inhibitory concentration: 21.2 nM
Beside the measured number, compound 4's estimate is 99-fold (2.00 log units) above it; the measured number lies below the stated range.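

In this assay the new step is a 42-fold lower number from compound 3 to compound 4 (1.62 log units; beyond the scatter), which runs in the opposite direction to the step seen on the core of compound 1. The same kind of change therefore gave clearly different results on the two cores, and the first result could not simply be carried over to the second: the same change on two cores in this assay, a 2.4-fold higher number (0.38 log units; beyond the scatter) from compound 1 to compound 2 and a 42-fold lower number (1.62 log units; beyond the scatter) from compound 3 to compound 4, 100-fold (2.00 log units) apart, beyond the scatter of two such steps

This does not show why the steps differ: the two pairs differ both in their core and in where the trifluoromethyl group sits, with the group in compound 4 meta to a large group, and four compounds cannot separate those two differences.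

Going by these compounds, it remains open whether moving trifluoromethyl on either core to the place it holds on the other would bring the step closer to that core's partner pair. On these data alone, it is also open whether a nitrile or a methoxy group put in place of methyl would follow the pattern of compound 2 or that of compound 4.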